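The source may report more compounds than this note shows. Statements on the series, on what has been measured and on what is new or still open speak of the compounds shown alone.

Working notes on a physicochemical assay for solubility, read by spectrophotometry, in phosphate buffer, with a stated time of 2 h, at pH 7.4; on this read-out lower numbers stand for lower solubility and higher numbers for higher solubility. Within the data shown here, compound 1 `COc1ccc2[nH]c(C(=O)N3CC(=O)N(Cc4ccccc4)[C@@H](COCc4ccccc4)C3)cc2c1` gives 8800 nM in this assay, the lowest of the three numbers measured so far. Compound 2 `COc1ccc2[nH]c(C(=O)N3CC(=O)N(Cc4ccccc4)[C@@H](CN4CCN(c5ccc(F)cc5)CC4)C3)cc2c1` gives 20700 nM, a number beyond the scatter above compound 1, and compound 3 `COc1ccc2[nH]c(C(=O)N3CC(=O)N(Cc4cccc(OC(F)F)c4)[C@@H](CN4CCCCC4)C3)cc2c1` gives 26400 nM, likewise beyond the scatter above compound 1. Compound 4 `COc1ccc2[nH]c(C(=O)N3CC(=O)N(Cc4ccccc4)[C@@H](CN4CCCc5ccccc54)C3)cc2c1` is not yet measured. Against compound 1 the change is 1,2,3,4-tetrahydroquinolin-1-yl in place of benzyloxy on a saturated chain carbon bound to a saturated ring carbon. Among the measured compounds shown here, no measured pair isolates this change, so the expectation rests on compound 1 alone. The expected step is a 1.3-fold lower number from compound 1 to compound 4 (0.10 log units; within the scatter), small, with no direction that is expected to clear the scatter. Compound 4 is therefore estimated at 7000 nM, with a range from 2500 nM to 20000 nM.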

Compound 4, solubility: 8500 nM
Compound 4: the middle estimate sits 1.2-fold (0.08 log units) below what was measured; the measured number falls inside the stated range.
By their numbers in this assay, from the lowest: compounds 4 and 1 (each within the scatter of the next); then compounds 2 and 3 (each within the scatter of the next).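

On a saturated chain carbon bound to a saturated ring carbon, 1,2,3,4-tetrahydroquinolin-1-yl in place of benzyloxy gives, in this assay, a 1.0-fold lower number from compound 1 to compound 4 (0.02 log units; within the scatter). Among these compounds, this is the first single-place comparison, and it does not separate the two groups on this read-out, even though the entering group brings a second ring and nitrogen in place of oxygen. No measured information bears on the reason for this result.

On these data alone, whether a morpholine or a carboxylic acid on the same chain carbon would give a step beyond the scatter remains open.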